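The source may hold more compounds than are shown below. What is called first, only, known or untested is meant among the compounds shown, and "the series" means these compounds.

Compounds measured in a functional assay on B16-F10 cells (Mus musculus) for inhibition, read by MTT assay, with a stated time of 72 h; on this read-out lower numbers stand for stronger inhibition of growth and higher numbers for weaker inhibition of growth:
- compound 1, `CC(C)=CCC/C(C)=C/CC/C(C)=C/C(=O)NC(=N)NC(=O)C=C(C)C`: 7500 nM
- compound 2, `CC(C)=CC(=O)NC(=N)NC(=O)C=C(C)C`: 21300 nM
- compound 3, `CC(C)=CCC/C(C)=C/C(=O)NC(=N)NC(=O)C=C(C)C`: 25000 nM

Compound 3 gives the highest number of the three; compound 2 lies nearest, and the two are within the scatter of each other, while compound 1 lies furthest, with the step of a 3.3-fold higher number from compound 1 to compound 3 (0.52 log units; beyond the scatter) being beyond the scatter. Compound 4, `CC(C)=CCC/C(C)=C/C(=O)NC(=N)NC(=O)/C=C(\C)CCC=C(C)C`, differs from compound 3 in one place: 3-methylbut-2-en-1-yl in place of hydrogen on a saturated chain carbon bound to a double-bonded chain carbon.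

For the measured compounds named here, two measured steps bear on this change. The step of a 1.2-fold higher number from compound 2 to compound 3 (0.07 log units; within the scatter) is the same kind of addition, on the other acyl chain, and it stayed within the scatter. The step of a 3.3-fold higher number from compound 1 to compound 3 (0.52 log units; beyond the scatter), however, shows that removing the same group from the already longer chain weakened growth inhibition. From these, a small gain at most is expected for compound 4 in this assay, with the step of a 2.1-fold lower number from compound 3 to compound 4 (0.32 log units; beyond the scatter) likely lying near or just beyond the scatter. Compound 4 is therefore estimated at 12000 nM, within a range from 4000 nM to 30000 nM.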

Compound 4, concentration for 50% growth inhibition: 23800 nM
The estimate for compound 4 lay 2.0-fold (0.30 log units) below the measured number; the range from low to high includes it.
By their numbers in this assay, from the lowest: compound 1; then compounds 2, 4 and 3 (each within the scatter of the next).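

In this assay, adding 3-methylbut-2-en-1-yl at this position on the second acyl chain gives a 1.1-fold lower number from compound 3 to compound 4 (0.02 log units; within the scatter), so this addition, like a 1.2-fold higher number from compound 2 to compound 3 (0.07 log units; within the scatter), stays within the scatter. The earlier compounds had shown a change beyond the scatter only for the same group on the already longer chain, in a 3.3-fold higher number from compound 1 to compound 3 (0.52 log units; beyond the scatter), so the result shows that the same group on the second chain does not repeat that step, and among these compounds the effect depends on which chain carries it. Nothing presented here accounts for this difference between the two chains. On these data alone, it remains open whether a still longer chain on the second acyl group would shift the number as it did on the first. Also open, as far as these compounds go, is how an amine or a carboxylic acid at this position would read out.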